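Sulfonylamino in place of aryl imine on a shared core

This account rests on a few compounds, and the source may have more. Where it says the series, first, only, none or still open, it means among the compounds named here.

Measured so far:
compound 1 `O=C1Nc2ccc(S(=O)(=O)N3CCOCC3)cc2/C1=N/c1ccc(O)cc1`: 52700 nM
compound 2 `Cc1ccc(S(=O)(=O)N/N=C2\C(=O)Nc3ccc(S(=O)(=O)N4CCOCC4)cc32)cc1`: 38400 nM

Going by the values given here, in a functional assay on MCF7 cells (Homo sapiens) for cytotoxicity, read by sulforhodamine B assay, with a stated time of 24 h (on this read-out lower numbers stand for stronger inhibition and higher numbers for weaker inhibition), compound 1 gives 52700 nM, the highest of the two numbers known. Compound 2 gives 38400 nM in this assay; the two values lie within the scatter of each other, so nothing separates compound 1 from compound 2 on this read-out. Both numbers sit in the same weak range.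

Compound 3 `O=C1Nc2ccc(S(=O)(=O)N3CCOCC3)cc2/C1=N/NS(=O)(=O)c1ccccc1` is not yet measured. It differs from compound 1 at a single place: (phenylsulfonyl)amino in place of 4-hydroxyphenyl on a double-bonded nitrogen. Compound 2 is the closer structural relative of compound 3, and its value in this assay is the better guide to what compound 3 may give.

Among the compounds with values here, no step between measured compounds is known, so no direction is fixed by the data. The expectation is that the step from compound 1 to compound 3 in this assay stays within the scatter, as an estimated change of a 1.3-fold lower number from compound 1 to compound 3 (0.10 log units; within the scatter). Compound 3 is accordingly estimated at 42000 nM in this assay, with a range from 15000 nM to 110000 nM.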

Compound 3, half-maximal inhibitory concentration: 25300 nM
Estimate against measurement, compound 3: 1.7-fold (0.22 log units) above, and the stated range covers the measured number.
By their numbers in this assay, from the lowest: compounds 3, 2 and 1 (each within the scatter of the next, the first and the last beyond it).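

In this assay compound 3 gives 25300 nM, and the double-bonded nitrogen of the shared core now has its first readable step: (phenylsulfonyl)amino in place of 4-hydroxyphenyl gives a 2.1-fold lower number from compound 1 to compound 3 (0.32 log units; beyond the scatter), a modest step that does show this position responds to the change of group. Hydrogen in place of methyl on an aromatic carbon gives a 1.5-fold lower number from compound 2 to compound 3 (0.18 log units; within the scatter), so the methyl makes no difference that can be read on this read-out, and the (phenylsulfonyl)amino compounds stand together on this evidence. No measurement at hand accounts for either step.

Still open, on these data alone, is how a group on this nitrogen without an aromatic ring, such as a simple amine or a methylsulfonylamino group, would read in this assay. As far as these compounds go, it is also open whether a substituent other than methyl on the phenyl ring of the sulfonyl group, such as a carboxylic acid or an amine, would move the number beyond the scatter.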